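The source may report more compounds than this note shows. Statements on the series, on what has been measured and on what is new or still open speak of the compounds shown alone.

Compound 1 `COc1ccc(COc2ccc(OCCOCCNC3CCCC3)cc2)cc1`: 15700 nM
Compound 2 `Clc1ccc(COc2ccc(OCCOCCNC3CCCCC3)cc2)cc1`: 2650 nM
Compound 3 `c1ccc(COc2ccc(OCCOCCNc3ccccc3)cc2)cc1`: > 100000 nM, which is a limit of the assay

All three entries come from a functional assay on SK-OV-3 cells (Homo sapiens) for inhibition, read by CCK-8 assay, with a stated time of 70 h; a higher number here means a weaker inhibitor, a lower number a stronger inhibitor. The entry for compound 3 is a limit and not a number. That leaves two numbers, and compound 1 has the higher of them, which makes it the weaker inhibitor of that pair. The gap down to compound 2 lies beyond the scatter, but these two compounds differ in more than one place.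

Compound 4 `Nc1ccc(COc2ccc(OCCOCCNC3CCCC3)cc2)cc1` is the next to be measured. It keeps the rest of compound 1 and carries amino in place of methoxy on an aromatic carbon, para to a large group (amino in place of methoxy on an aromatic carbon). For the measured compounds named here, no measured pair isolates this change, so the expectation starts from compound 1 at 15700 nM. In this assay, the estimated step of a 1.1-fold higher number from compound 1 to compound 4 (0.06 log units; within the scatter) is expected to stay within the scatter, with no firm direction. Compound 4 is expected at 18000 nM, with an estimated range from 5000 nM to 60000 nM.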

Compound 4, half-maximal inhibitory concentration: 31700 nM
Beside the measured number, compound 4's estimate is 1.8-fold (0.25 log units) below it; low and high end bracket the measured number.
By their numbers in this assay, from the lowest: compound 2; then compound 1; then compound 4. At a limit, above all of these: compound 3.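

In this assay, amino in place of methoxy on the aromatic carbon, para to a large group, gives a 2.0-fold higher number from compound 1 to compound 4 (0.31 log units; beyond the scatter), a modest step. This is the only pair shown that differs in one place, so it shows for the first time that the number responds to a change at this position alone: the earlier compounds differed in more than one place and could not show this. The change removes one heavy atom and adds one hydrogen-bond donor, but nothing measured here gives a reason for the step.

Going by these compounds, what remains open is how a hydroxyl or a dimethylamino group would read on this carbon, and whether the step would hold with another group at the far end of the chain. On these data alone, it is also open how chloro would read with the rest of compound 1 kept.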